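Swapping pyrimidine for thiophene and cytotoxicity toward kidney cells

The source may hold more compounds than are shown below. What is called first, only, known or untested is meant among the compounds shown, and "the series" means these compounds.

Compound 1 `C[C@H]1[C@H](NCc2cc(Br)cs2)C[C@H]2C[C@@H]1C2(C)C` and compound 2 `C[C@H]1[C@H](NCc2cncnc2)C[C@H]2C[C@@H]1C2(C)C` share the same core and differ only in the aromatic ring carried on the saturated chain carbon bound to the amine nitrogen. In an ADME assay on MDCK cells (Canis lupus familiaris) for cytotoxicity, read by microscopy, with a stated time of 48 h (on this read-out lower numbers stand for higher toxicity in this test and higher numbers for lower toxicity in this test), compound 1 gives 6250 nM. In this assay compound 2 gives > 100000 nM, which is a limit of the test rather than a measured number. The step is an at least 16-fold higher number from compound 1 to compound 2 (1.20 log units; beyond the scatter), so compound 2 stands at the limit of > 100000 nM in this assay, at which 1 of the 2 values shown sits, the top of the numbers shown.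

Compound 3 `C[C@H]1[C@H](NCc2ccsc2)C[C@H]2C[C@@H]1C2(C)C` has not yet been measured. It differs from compound 2 by thiophen-3-yl in place of pyrimidin-5-yl on a saturated chain carbon bound to an amine nitrogen. Within the data shown here, the only measured step that bears on this change runs the other way, from 4-bromothiophen-2-yl to pyrimidin-5-yl, and it was large: an at least 16-fold higher number from compound 1 to compound 2 (1.20 log units; beyond the scatter). Putting a thiophene back is therefore expected to lower the number, meaning higher toxicity, in this assay. Compound 3 lacks the bromine of compound 1, so only part of that move back is expected, estimated as an at least 4.0-fold lower number from compound 2 to compound 3 (0.60 log units; beyond the scatter). Compound 3 is thus expected to show 25000 nM, within a range from 8000 nM to 100000 nM.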

Compound 3, minimum cytotoxic concentration: 50000 nM
For compound 3 the middle estimate is 2.0-fold (0.30 log units) below the measured one; the range from low to high includes it.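

A thiophene ring at this place does not by itself bring back the toxicity seen with the bromine-bearing group: the change gives an 8.0-fold higher number from compound 1 to compound 3 (0.90 log units; beyond the scatter). The swap of the two unsubstituted rings is less clear. It reads an at least 2.0-fold lower number from compound 2 to compound 3 (0.30 log units; that floor lies within the scatter), so no real difference between thiophen-3-yl and pyrimidin-5-yl can be claimed in this assay, and the value of compound 2 is a limit, not a number: the limit of > 100000 nM in this assay, at which 1 of the 3 values shown sits.

Thiophen-3-yl and 4-bromothiophen-2-yl differ in more than the bromine, so these compounds cannot say how much of the step comes from the bromine itself and how much from the way the ring is attached; a thiophen-2-yl group without bromine would separate the two. From the compounds shown here alone, how a plain phenyl ring, or a ring carrying an amine or a carboxylic acid, would behave on this read-out also stays open.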